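Carbamoyl in Place of Amino on the Phenyl Ring

The compounds below may be only part of what the source reports. "The series", "measured", "known", "first", "only" and "open" are said of these compounds alone.

Three compounds have been measured in an assay (Rattus norvegicus) for inhibition of Fatty-acid amide hydrolase 1 (Homo sapiens); on this read-out lower numbers stand for stronger inhibition and higher numbers for weaker inhibition:
compound 1 `O=C(CCCCCCc1ccccc1)c1ncc(-c2ccccc2C(=O)C(F)(F)F)o1` gives 5000 nM
compound 2 `N#Cc1ccccc1-c1cnc(C(=O)CCCCCCc2ccccc2)o1` gives 130 nM
compound 3 `Nc1cccc(-c2cnc(C(=O)CCCCCCc3ccccc3)o2)c1` gives 19 nM

All three share the same core and differ only in the group carried on the phenyl ring attached to that core. Compound 3 stands lowest of the three numbers in this assay; its nearest neighbour is compound 2, and the step of a 6.8-fold lower number from compound 2 to compound 3 (0.84 log units; beyond the scatter) lies beyond the scatter. The earlier step, a 38-fold lower number from compound 1 to compound 2 (1.59 log units; beyond the scatter), was larger still. Both steps show that this phenyl substituent matters a great deal.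

Compound 4 `NC(=O)c1cccc(-c2cnc(C(=O)CCCCCCc3ccccc3)o2)c1` is the next step from compound 3: carbamoyl in place of amino on an aromatic carbon. For the measured compounds named here, no measured pair shows exactly this swap, so the two earlier steps are the only guide, and they say only that changes here can be large in either direction. A moderate shift toward a higher number is expected, a 2.1-fold higher number from compound 3 to compound 4 (0.32 log units; beyond the scatter), with wide uncertainty. The estimate for compound 4 in this assay is 40 nM, within a range from 10 nM to 160 nM.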

Compound 4, inhibition constant: 6 nM
Compound 4: middle estimate off by 6.7-fold (0.82 log units), on the high side; measured number outside the range, below it.
By their numbers in this assay, from the lowest: compound 4; then compound 3; then compound 2; then compound 1.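

In this assay, a 3.2-fold lower number from compound 3 to compound 4 (0.50 log units; beyond the scatter) shows that amino is not the group giving the lowest number at this position, since carbamoyl, a larger group with three heavy atoms rather than one, goes lower still. The a 22-fold lower number from compound 2 to compound 4 (1.34 log units; beyond the scatter) is larger, but it changes both the group and its name-given place on the phenyl ring, so it cannot be credited to either change alone. Nothing measured here explains why carbamoyl gives the lower number.

Still open, on these data alone, is how a carboxylic acid or a methyl ester would read at this same place on the ring. Also open, as far as these compounds go, is whether the carbamoyl step would hold if the amide hydrogens were replaced by methyl groups.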